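From Methoxy to Hydroxy: What to Expect of Compound 4

This account rests on a few compounds, and the source may have more. Where it says the series, first, only, none or still open, it means among the compounds named here.

Three compounds have been measured in a functional assay on NCI-H460 cells (Homo sapiens) for inhibition, read by sulforhodamine B assay, with a stated time of 48 h; on this read-out higher numbers stand for weaker inhibition of growth and lower numbers for stronger inhibition of growth:

Compound 1, `COc1cc(-c2nn(-c3cccc(NC(=O)c4ccc(Cl)c(C(F)(F)F)c4)c3)cc2-c2ccncc2)ccc1Cl`, gives 3470 nM.
Compound 2, `COc1cc(-c2nn(-c3cccc(NC(=O)Nc4cccc(C(F)(F)F)c4)c3)cc2-c2ccncc2)ccc1Cl`, gives 763 nM.
Compound 3, `COc1cc(-c2nn(-c3cccc(NC(=O)Nc4ccc(Cl)c(C(F)(F)F)c4)c3)cc2-c2ccncc2)ccc1Cl`, gives 1110 nM.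

Compound 3 stands second highest of the three numbers. Its nearest neighbour is compound 2, and the step of a 1.5-fold higher number from compound 2 to compound 3 (0.16 log units; within the scatter) is within the scatter, so the two cannot be ordered. Its furthest neighbour is compound 1, and the step of a 3.1-fold lower number from compound 1 to compound 3 (0.50 log units; beyond the scatter) is beyond the scatter, as is the related step of a 4.5-fold lower number from compound 1 to compound 2 (0.66 log units; beyond the scatter).

Compound 4, `O=C(Nc1cccc(-n2cc(-c3ccncc3)c(-c3ccc(Cl)c(O)c3)n2)c1)Nc1ccc(Cl)c(C(F)(F)F)c1`, differs from compound 3 in one place: hydrogen in place of methyl on an oxygen on an aromatic ring. Cut one bond further out, the change reads methoxy to hydroxy, on the 4-chloro-3-methoxyphenyl side of the shared core.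

Among the compounds with values here, none of the measured steps bears on this change. The two steps from compound 1 concern the group on the carbonyl carbon, and the step from compound 2 to compound 3 concerns a chloro on the other aromatic ring. Nothing measured here touches the oxygen on the aromatic ring. With no guidance from the data, compound 4 is expected to give a step of a 1.0-fold lower number from compound 3 to compound 4 (0.00 log units; within the scatter), that is, none beyond the scatter, in this assay. Compound 4 is therefore estimated at 1100 nM, with a range of 350 nM to 3500 nM.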

Compound 4, concentration for 50% growth inhibition: 1010 nM
Beside the measured number, compound 4's estimate is 1.1-fold (0.04 log units) above it; measured number inside the range.
By their numbers in this assay, from the lowest: compounds 2, 4 and 3 (each within the scatter of the next); then compound 1.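

In this assay, the change from methoxy to hydroxy on the 4-chloro-3-methoxyphenyl side of the shared core amounts to a 1.1-fold lower number from compound 3 to compound 4 (0.04 log units; within the scatter), so removing the methyl from this oxygen leaves no difference that this read-out can separate from the scatter. Within the data shown here, the earlier compounds varied only the group on the carbonyl carbon and a chloro on the other aromatic ring, so this is the first reading at this oxygen, and it shows that the growth inhibition seen with compound 3 does not depend on that methyl in this assay. No accompanying measurement bears on what lies behind this result.

The compounds shown leave open whether the same holds for this change with the other groups on the carbonyl carbon, since the hydroxy appears only on the scaffold of compound 3. They also leave open what a larger or different group at this place would do, such as an ethoxy or a longer chain on the oxygen, or an amine or a carboxylic acid on the aromatic carbon in place of the oxygen.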